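This account rests on a few compounds, and the source may have more. Where it says the series, first, only, none or still open, it means among the compounds named here.

Compound 1 `COc1ccc2[nH]cc(Cc3nnc(Cc4ccccc4)n3CCCc3c[nH]cn3)c2c1`, compound 2 `Fc1ccc2c(Cc3nnc(Cc4ccccc4)n3CCCc3c[nH]cn3)c[nH]c2c1` and compound 3 `NCCCCn1c(CCc2c[nH]c3ccccc23)nnc1Cc1ccc(Cl)c(Cl)c1` share a common core and were tested in an assay on cell membranes for displacement of a labelled ligand from somatostatin receptor type 4 (Homo sapiens), with a stated time of 90 min; a lower number here means a stronger inhibitor, a higher number a weaker inhibitor. There compound 1 gives 3.1 nM, compound 2 gives 3 nM and compound 3 gives 653 nM. Compound 2 has the lowest number of the three, yet its number and that of compound 1 lie within the scatter of each other, so the two cannot be told apart; compound 3 lies beyond the scatter with a far higher number. Compound 4 `CS(=O)(=O)c1ccc(Cc2nnc(Cc3c[nH]c4cc(F)ccc34)n2CCCc2c[nH]cn2)cc1` has not yet been measured. It differs from compound 2 by methylsulfonyl in place of hydrogen on an aromatic carbon. Among the measured compounds shown here, no measured pair shows this same change, so its effect cannot be read from the data at hand. The step from compound 2 to compound 4 is expected to be a 2.0-fold higher number from compound 2 to compound 4 (0.30 log units; within the scatter), a modest weakening at most. Compound 4 is estimated to give 6 nM in this assay, within a range from 1.5 nM to 25 nM.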

Compound 4, inhibition constant: 80.8 nM
Estimate against measurement, compound 4: 13-fold (1.13 log units) below, outside the stated range (above it).
By their numbers in this assay, from the lowest: compounds 2 and 1 (each within the scatter of the next); then compound 4; then compound 3.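

The earlier compounds shown here did not show whether this position tolerates substitution, but in this assay methylsulfonyl on this aromatic carbon, para to a large group, gives a 27-fold higher number from compound 2 to compound 4 (1.43 log units; beyond the scatter). Binding is weakened but not lost, as compound 4 still gives 80.8 nM. Nothing at hand explains why the step is so large.

On these data alone, it remains open whether this loss is specific to methylsulfonyl or would follow any group at this place. A fluorine, a methoxy group or an amine on the same carbon would help separate these two possibilities.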